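Phenyl in Place of Chloromethyl: Where Compound 3 May Land

A few compounds are considered here, and "the series" means these few. Any claim that something is new, unique, unknown or untested is made for them only; others in the source may bear on it.

Compound 1 `Cc1c[se]c(N/N=C/c2ccc(Cl)cc2)n1` was tested in a functional assay on HepG2 cells (Homo sapiens) for cytotoxicity, read by XTT assay, with a stated time of 72 h (a higher number here means a weaker inhibitor, a lower number a stronger inhibitor), where compound 1 gives 56500 nM. Compound 2 `ClCc1c[se]c(N/N=C/c2ccc(Cl)cc2)n1` carries a chloro in place of hydrogen on a saturated chain carbon bound to an aromatic carbon. In this assay compound 2 reaches only a limit of the assay, > 75000 nM. The step of an at least 1.3-fold higher number from compound 1 to compound 2 (0.12 log units; that floor lies within the scatter) is thus known only as a floor, and compound 2 stands at the limit of > 75000 nM in this assay, at which 1 of the 2 values shown sits. Compound 3 `Clc1ccc(/C=N/Nc2nc(-c3ccccc3)c[se]2)cc1` carries phenyl in place of chloromethyl on an aromatic carbon. Among the measured compounds shown here, no measured step touches this change; the one known step concerns the chloro on the chain, and its floor lies within the scatter. Nothing in the data therefore points to a step beyond the scatter in either direction in this assay. For compound 3 the expected step is an at least 1.2-fold lower number from compound 2 to compound 3 (0.09 log units; that floor lies within the scatter). Compound 3 is estimated at 60000 nM, within 20000 nM to 200000 nM.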

Compound 3, half-maximal inhibitory concentration: 42500 nM
Estimate against measurement, compound 3: 1.4-fold (0.15 log units) above; low and high end bracket the measured number.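

In this assay, the aromatic carbon next to the ring nitrogen now carries phenyl, a group with a six-membered aromatic ring, and compound 3 gives a measured number, which compound 2 does not. Set against methyl, the change reads in full as a 1.3-fold lower number from compound 1 to compound 3 (0.12 log units; within the scatter), so phenyl and methyl are not told apart at this position. Set against chloromethyl, it reads only as an at least 1.7-fold lower number from compound 2 to compound 3 (0.24 log units; that floor lies within the scatter), because compound 2 stands at a limit of the assay and not at a number: the limit of > 75000 nM in this assay, at which 1 of the 3 values shown sits.

The compounds shown leave open whether an amine, a carboxylic acid or a longer chain on this aromatic carbon would give a step beyond the scatter. They also leave open where the true number of compound 2 lies.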